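Changing the ring on a shared core

The source may report more compounds than this note shows. Statements on the series, on what has been measured and on what is new or still open speak of the compounds shown alone.

For the measured compounds named here, in an ADME assay on microsomes from liver (Homo sapiens) for metabolic stability, read by LC-MS, using NADPH, with stated times of 5 min and 30 min, tested at 1 uM (a higher number here means faster removal of the compound, a lower number slower removal), compound 1 `CNC(=O)c1ncc(-c2cnc(NCc3c(F)ccc4c3CCO4)c3cn[nH]c(=O)c23)n1C` gives 24 mL.min-1.g-1 and compound 2 `CNC(=O)c1ccc(-c2cnc(NCc3c(F)ccc4c3CCO4)c3cn[nH]c(=O)c23)c(C)n1` gives 23 mL.min-1.g-1, so compound 2 stands level with the only other measured compound. Compound 3 `Cc1nn(C)cc1-c1cnc(NCc2c(F)ccc3c2CCO3)c2cn[nH]c(=O)c12` has 1,3-dimethyl-1H-pyrazol-4-yl in place of 2-methyl-6-(methylcarbamoyl)pyridin-3-yl on an aromatic carbon. Going by the values given here, the only measured swap at this place is the step of a 1.0-fold lower number from compound 1 to compound 2 (0.02 log units; within the scatter), which lies within the scatter. Both of those groups contain methylcarbamoyl and the entering group does not, so this guide is weak. The expected step is a 1.1-fold higher number from compound 2 to compound 3 (0.04 log units; within the scatter), with no change beyond the scatter and no firm direction. The estimate for compound 3 is 25 mL.min-1.g-1, with an expected range of 12 mL.min-1.g-1 to 50 mL.min-1.g-1.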

Compound 3, intrinsic clearance in microsomes in the Homo sapiens assay: 27 mL.min-1.g-1
Compound 3: the middle estimate sits 1.1-fold (0.03 log units) below what was measured; low and high end bracket the measured number.
By their numbers in the Homo sapiens assay, from the lowest: compounds 2, 1 and 3 (each within the scatter of the next).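

In the Homo sapiens assay the number holds when 1,3-dimethyl-1H-pyrazol-4-yl enters, with a 1.2-fold higher number from compound 2 to compound 3 (0.07 log units; within the scatter) and a 1.1-fold higher number from compound 1 to compound 3 (0.05 log units; within the scatter), so this position now carries three different rings, one without methylcarbamoyl, with no change beyond the scatter. In a physicochemical assay for solubility, read by LC-MS, in phosphate buffer, with a stated time of 24 h, at pH 7.4 (on this read-out higher numbers stand for higher solubility and lower numbers for lower solubility), compound 2 gives 19000 nM and compound 3 gives 9000 nM. The same swap does register in the physicochemical assay: the measured solubility of compound 2, 19000 nM, and of compound 3, 9000 nM, a 2.1-fold lower number (0.32 log units; beyond the scatter). The compounds shown leave open which part of this swap goes with that step, the loss of methylcarbamoyl or the change of ring. They also leave open how a five-membered aromatic ring carrying an amine or a carboxylic acid would read in either assay.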